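This account rests on a few compounds, and the source may have more. Where it says the series, first, only, none or still open, it means among the compounds named here.

Among the measured compounds shown here, in a physicochemical assay for lipophilicity, using the shake flask method, at pH 7.4 (on this read-out higher numbers stand for higher lipophilicity and lower numbers for lower lipophilicity), compound 3 `COC(=O)N1CCN([C@H]2CC[C@H](Nc3ncnn4ccc([C@H](C)CC(N)=O)c34)CC2)CC1` gives 1.9, the lowest of the three numbers so far. Compound 1 `COC(=O)N1CCN([C@H]2CC[C@H](Nc3ncnn4ccc([C@H](C)CC(=O)N(C)C)c34)CC2)CC1` gives 2.3 and compound 2 `CC(=O)N1CCN([C@H]2CC[C@H](Nc3ncnn4ccc(C(C)C)c34)CC2)CC1` gives 2.4, and these two values lie within the scatter of each other.

The change under consideration leads to compound 4 `COC(=O)N1CCN([C@H]2CC[C@H](Nc3ncnn4ccc(C(C)C)c34)CC2)CC1`: hydrogen in place of carbamoyl on a saturated chain carbon, two bonds along the chain from an aromatic carbon. This is hydrogen in place of carbamoyl on a saturated chain carbon, two bonds along the chain from an aromatic carbon, so 1-(carbamoylmethyl)ethyl becomes isopropyl.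

For the measured compounds named here, only one measured step touches this chain: a number 0.40 log units lower from compound 1 to compound 3 (beyond the scatter), modest but beyond the scatter, with amino in place of dimethylamino on a carbonyl carbon. That step alters the group on the carbonyl carbon only. Going by the values given here, no measured step removes the carbamoyl as a whole, so its size serves as a loose guide and not as a direct precedent. A second reference is compound 2, which also carries isopropyl and gives 2.4, a number above that of compound 3.

Among the compounds with values here, a rise larger than the one step on this chain is therefore expected in this assay: a number 1.00 log units higher from compound 3 to compound 4 (beyond the scatter). For compound 4 the estimated value is 2.9, with an expected range of 2.5 to 3.3.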

Compound 4, distribution coefficient: 3.3
Beside the measured number, compound 4's estimate is 0.40 log units below it; the range from low to high includes it.
By their numbers in this assay, from the lowest: compound 3; then compounds 1 and 2 (each within the scatter of the next); then compound 4.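

Working notes on the series: in this assay, removal of the whole side-chain amide at this place moves the number much further than the change on its carbonyl carbon alone (compare a number 1.40 log units higher from compound 3 to compound 4 (beyond the scatter) and a number 1.00 log units higher from compound 1 to compound 4 (beyond the scatter) with a number 0.40 log units lower from compound 1 to compound 3 (beyond the scatter)), so hydrogen in place of carbamoyl on a saturated chain carbon, two bonds along the chain from an aromatic carbon, is a large change in this read-out. Among the compounds shown here, with isopropyl held constant, the carbonyl substituent at the other end of the molecule also matters, since methoxy in place of methyl on a carbonyl carbon gives a step beyond the scatter (in this assay, a number 0.90 log units higher from compound 2 to compound 4 (beyond the scatter)), a place that the earlier steps did not touch. No measurement at hand gives a reason for the size of any of these steps.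

Going by these compounds, it remains open where a carboxylic acid, an amine or a longer chain at this place would fall relative to compound 3 and compound 4. On these data alone, it is also open whether the step from 1-(carbamoylmethyl)ethyl to isopropyl would keep its size with an acetyl group in place of the methyl carbamate on the core of compound 2.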